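Mirror-image twin of a non-toxic bis-dioxane chain

This account rests on a few compounds, and the source may have more. Where it says the series, first, only, none or still open, it means among the compounds named here.

Compound 1 `C(C[C@@H]1COCCO1)C[C@@H]1COCCO1` gives > 1000000 nM, a limit of the assay rather than a number.
Compound 2 `OC(C[C@@H]1COCCO1)C[C@@H]1COCCO1` gives > 1000000 nM, likewise a limit.
Compound 3 `C1CSC(CC[C@@H]2COCCO2)(C[C@@H]2COCCO2)SC1` gives > 1000000 nM, again a limit.

In an ADME assay on BHK cells (Mesocricetus auratus) for cytotoxicity, read by XTT assay (on this read-out higher numbers stand for lower toxicity in this test and lower numbers for higher toxicity in this test), compound 1 therefore stands only at a limit, as do the other two measured compounds. Going by the values given here, the one readable comparison, a step that the two limits leave unreadable from compound 1 to compound 2, says nothing about size because the limit of > 1000000 nM in this assay, at which 3 of the 3 values shown sit, covers every value shown. Compound 4 `C(C[C@H]1COCCO1)C[C@H]1COCCO1` differs from compound 1 only in configuration: the two compounds have the same atoms and bonds and differ only in configuration as drawn: 2 of 2 stereo elements differ (all stereocentres are inverted: mirror images); a stereocentre at a saturated ring carbon is drawn R in compound 1 and S in compound 4; a stereocentre at a saturated ring carbon is drawn R in compound 1 and S in compound 4. Among the compounds with values here, no measured step concerns a change of configuration, so the expectation rests on compound 1 alone, which sits at the limit because the limit of > 1000000 nM in this assay, at which 3 of the 3 values shown sit, holds for it. Compound 4 is therefore expected to show no toxicity beyond the same limit, a step of a number no higher from compound 1 to compound 4 (the limit leaves the size open). The estimate for compound 4 is 1000000 nM, ranging from 300000 nM to 3000000 nM.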

Compound 4, half-maximal cytotoxic concentration: > 1000000 nM
Compound 4 was reported as a limit; the forecaster's own chance of this, stated with the estimate: 90%; the middle value sits exactly at the limit.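

No step can be read between compound 1 and compound 4, since both stand only at a limit: the limit of > 1000000 nM in this assay, at which 4 of the 4 values shown sit.

The compounds shown leave open whether the inverted configuration changes toxicity at all, and at what concentration, if any, these compounds harm the cells.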